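Aryl exchange on the shared core: compound 2 to compound 3

The source may report more compounds than this note shows. Statements on the series, on what has been measured and on what is new or still open speak of the compounds shown alone.

Measured in a functional assay on MCF7 cells (Homo sapiens) for antiproliferative activity, read by MTT assay, with a stated time of 72 h; a lower number here means a stronger inhibitor, a higher number a weaker inhibitor:
- compound 1 `COc1cc(-n2cnc3ccc(-c4cccc(O)c4)cc32)cc(OC)c1OC` gives 350 nM
- compound 2 `COc1cc(-n2cnc3ccc(-c4ccc(Cl)cc4)cc32)cc(OC)c1OC` gives 1320 nM

For the measured compounds named here, compound 2 holds the higher of the two numbers in this assay, and compound 1 is its only neighbour. Compound 3 `COc1cccc(-c2ccc3ncn(-c4cc(OC)c(OC)c(OC)c4)c3c2)c1` is not yet measured. Its difference from compound 2 is 3-methoxyphenyl in place of 4-chlorophenyl on an aromatic carbon, with 3-methoxyphenyl in place of 4-chlorophenyl on an aromatic carbon.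

Going by the values given here, only one measured step bears on this change: a 3.8-fold higher number from compound 1 to compound 2 (0.58 log units; beyond the scatter). It is modest and beyond the scatter. Compound 1, at 350 nM, carries 3-hydroxyphenyl, the closer relative by name of 3-methoxyphenyl. Part of that step is therefore expected to be recovered, giving a lower number than for compound 2, though two compounds make a thin basis. The estimated step is a 2.1-fold lower number from compound 2 to compound 3 (0.33 log units; beyond the scatter). For compound 3 the expected value is 620 nM, with an estimated range of 220 nM to 1700 nM.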

Compound 3, half-maximal inhibitory concentration: 1610 nM
Compound 3: the middle estimate sits 2.6-fold (0.41 log units) below what was measured; low and high end bracket the measured number.
By their numbers in this assay, from the lowest: compound 1; then compounds 2 and 3 (each within the scatter of the next).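

In this assay, 3-methoxyphenyl and 4-chlorophenyl at this position cannot be told apart, with a 1.2-fold higher number from compound 2 to compound 3 (0.09 log units; within the scatter). Compound 1 and compound 2 differ in both the substituent and its place on the ring, whereas compound 1 and compound 3 share the same place and differ only by methyl in place of hydrogen on the oxygen, which gives a 4.6-fold higher number from compound 1 to compound 3 (0.66 log units; beyond the scatter). Among these three compounds, only the free hydroxyl of compound 1 stands apart, so a meta oxygen alone does not keep the lower number. Nothing in hand explains this step.

As far as these compounds go, whether an amine or a carboxylic acid at the same place on the phenyl ring would match compound 1 remains open. So does the effect of moving the hydroxyl, as in 4-hydroxyphenyl.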